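This account rests on a few compounds, and the source may have more. Where it says the series, first, only, none or still open, it means among the compounds named here.

Measured so far in an ADME assay on MT4 cells (Homo sapiens) for inhibition, read by MTT assay, with a stated time of 5 days; a lower number here means that less compound is tolerated, a higher number that more compound is tolerated:
compound 1 `Cc1cc(C)c(Oc2cc(Nc3ccc(C#N)cc3)ncc2[N+](=O)[O-])c(C)c1` gives 69900 nM
compound 2 `Cc1cc(Br)cc(C)c1Oc1cc(Nc2ccc(C#N)cc2)ncc1[N+](=O)[O-]` gives 12300 nM
compound 3 `N#Cc1ccc(Nc2cc(Oc3c(Cl)cc(Cl)cc3Cl)c([N+](=O)[O-])cn2)cc1` gives 16200 nM

Compound 3 sits level with compound 2 (a 1.3-fold higher number from compound 2 to compound 3 (0.12 log units; within the scatter)) and clearly under compound 1 (a 4.3-fold lower number from compound 1 to compound 3 (0.63 log units; beyond the scatter)). Compound 4 `Cc1cc(Br)c(Oc2cc(Nc3ccc(C#N)cc3)ncc2[N+](=O)[O-])c(Br)c1` is not yet measured, and it differs from compound 3 in one place (2,6-dibromo-4-methylphenyl in place of 2,4,6-trichlorophenyl on an oxygen on an aromatic ring). The entering 2,6-dibromo-4-methylphenyl carries both bromo and methyl, as does the 4-bromo-2,6-dimethylphenyl of compound 2.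

Two measured steps away from the 2,4,6-trimethylphenyl of compound 1 bear on this. One is bromo in place of methyl on an aromatic carbon (a 5.7-fold lower number from compound 1 to compound 2 (0.75 log units; beyond the scatter)), and the other is the modest step to compound 3 noted above. Compound 4 is therefore expected to stay with compound 2 and compound 3 rather than with compound 1, with no step beyond the scatter expected in this assay. The estimated change is small (a 1.2-fold lower number from compound 3 to compound 4 (0.06 log units; within the scatter)). The expected value for compound 4 is 14000 nM within an estimated range of 6000 nM to 32000 nM for now.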

Compound 4, half-maximal cytotoxic concentration: 23600 nM
Compound 4: the middle estimate sits 1.7-fold (0.23 log units) below what was measured, and the stated range covers the measured number.
By their numbers in this assay, from the lowest: compounds 2, 3 and 4 (each within the scatter of the next); then compound 1.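

In this assay, the 2,6-dibromo-4-methylphenyl on the oxygen cannot be told apart from either the 2,4,6-trichlorophenyl (a 1.5-fold higher number from compound 3 to compound 4 (0.16 log units; within the scatter)) or the 4-bromo-2,6-dimethylphenyl (a 1.9-fold higher number from compound 2 to compound 4 (0.28 log units; within the scatter)), so exchanging among these three halogen-bearing groups at this position leaves the reading within the scatter. The step from the all-methyl group stays beyond the scatter with this third halogen-bearing group (a 3.0-fold lower number from compound 1 to compound 4 (0.47 log units; beyond the scatter)), which places every halogen-bearing compound shown apart from compound 1. No measurement at hand bears on what lies behind this grouping.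

On these data alone, it remains open whether the grouping extends to other halogen patterns, such as a 2,4,6-trifluorophenyl, at this position. Also open, as far as these compounds go, is how the tolerated concentration responds to an amine or a carboxylic acid on this aromatic ring.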